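Working notes: from compound 1 to compound 3

The source may hold more compounds than are shown below. What is called first, only, known or untested is meant among the compounds shown, and "the series" means these compounds.

Measured in a functional assay on the whole organism for inhibition, with Rattus norvegicus as the target; a higher number here means that more compound is needed for the effect, a lower number that less compound is needed:
- compound 1 `O=C1N(CCN2CCC(c3cn(-c4ccc(F)cc4)c4ccc(Cl)cc34)CC2)CCN1c1ccccc1`: > 0.15 umol/kg (a limit)
- compound 2 `Cc1ccc2c(c1)c(C1CCN(CCN3CCNC3=O)CC1)cn2-c1ccc(F)cc1`: 0.0083 umol/kg

Compound 1 has no numerical value in this assay, only the limit > 0.15 umol/kg. As far as these compounds go, its true position therefore remains open.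

Compound 3 `O=C1NCCN1CCCCCN1CCC(c2cn(-c3ccc(F)cc3)c3ccc(Cl)cc23)CC1` follows from compound 1 through one change, 3-(2-oxoimidazolidin-1-yl)propyl in place of 2-oxo-3-phenylimidazolidin-1-yl on a saturated chain carbon, two bonds along the chain from an amine nitrogen in a ring.

For the measured compounds named here, no measured step gauges this change. A moderate step toward lower values in this assay is nevertheless expected, with wide uncertainty, since compound 2 at 0.0083 umol/kg shows that low values occur in the series. The expected change is an at least 3.0-fold lower number from compound 1 to compound 3 (0.47 log units; beyond the scatter). For compound 3 the estimated value is 0.05 umol/kg, with an expected range of 0.008 umol/kg to 0.3 umol/kg.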

Compound 3, dose for half-maximal effect: 1.5 umol/kg
For compound 3 the middle estimate is 30-fold (1.48 log units) below the measured one; measured number above the stated range.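

Compound 1 is held only as a limit, so no step from it to compound 3 can be read in this assay: the limit of > 0.15 umol/kg in this assay, at which 1 of the 3 values shown sits.

The compounds shown leave open how far, and in which direction, 3-(2-oxoimidazolidin-1-yl)propyl in place of 2-oxo-3-phenylimidazolidin-1-yl moves the number.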